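Compound 4: a new group on a level series

The source may hold more compounds than are shown below. What is called first, only, known or untested is meant among the compounds shown, and "the series" means these compounds.

Of the compounds shown here, three sharing one core have been tested so far. In a functional assay on MCF7 cells (Homo sapiens) for cytotoxicity, read by MTT assay, with a stated time of 72 h (on this read-out higher numbers stand for weaker inhibition and lower numbers for stronger inhibition), compound 1 `O=C(N/N=C/c1ccc(F)cc1Cl)Nc1cc2c(Nc3ccc(F)c(Cl)c3)ncnc2cc1O[C@H]1CCOC1` gives 32200 nM while compound 2 `COc1ccc(/C=N/NC(=O)Nc2cc3c(Nc4ccc(F)c(Cl)c4)ncnc3cc2O[C@H]2CCOC2)cc1` gives 27300 nM and compound 3 `COc1ccc(/C=N/NC(=O)Nc2cc3c(Nc4ccc(F)c(Cl)c4)ncnc3cc2O[C@H]2CCOC2)c(OC)c1OC` gives 33800 nM on the same scale. Compound 3 therefore sits level with the other two, since all three values lie within the usual scatter of repeated measurements. The next candidate is compound 4 `O=C(N/N=C/c1ccc(O)cc1O)Nc1cc2c(Nc3ccc(F)c(Cl)c3)ncnc2cc1O[C@H]1CCOC1` with the change 2,4-dihydroxyphenyl in place of 2,3,4-trimethoxyphenyl on a carbon with a double bond to nitrogen in one place. In words, 2,4-dihydroxyphenyl stands in place of 2,3,4-trimethoxyphenyl on a carbon with a double bond to nitrogen. Among the compounds with values here, three measured steps bear on this same place: a 1.2-fold lower number from compound 1 to compound 2 (0.07 log units; within the scatter) and a 1.0-fold higher number from compound 1 to compound 3 (0.02 log units; within the scatter) and also a 1.2-fold higher number from compound 2 to compound 3 (0.09 log units; within the scatter) and each of them stays within the scatter. Swapping the group here has so far left the number unmoved, so no step beyond the scatter is expected in this assay this time. Within the data shown here, none of the measured compounds carries a hydroxyl group there, however, so the range has to stay wide. The expected size of the change is a 1.4-fold lower number from compound 3 to compound 4 (0.13 log units; within the scatter) and that remains a modest move. Compound 4 is estimated at 25000 nM with an expected range from 8000 nM to 55000 nM for repeated measurements.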

Compound 4, half-maximal inhibitory concentration: 5350 nM
Compound 4: the middle estimate sits 4.7-fold (0.67 log units) above what was measured; measured number outside the range, below it.
By their numbers in this assay, from the lowest: compound 4; then compounds 2, 1 and 3 (each within the scatter of the next).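

In this assay this position turns out not to be indifferent to what it carries. Within the data shown here, the earlier aryl groups stayed within the scatter of one another, yet 2,4-dihydroxyphenyl gives a 6.3-fold lower number from compound 3 to compound 4 (0.80 log units; beyond the scatter) and a 5.1-fold lower number from compound 2 to compound 4 (0.71 log units; beyond the scatter) as well as a 6.0-fold lower number from compound 1 to compound 4 (0.78 log units; beyond the scatter), so compound 4 is the only compound here that stands apart from the rest, and all three of its steps point the same way. Compound 4 is also the only one of the four with hydroxyl groups on this ring, and those groups bring hydrogen-bond donors where 2,3,4-trimethoxyphenyl has none, but this is a coincidence of structure and result, and nothing measured on these compounds gives a reason for the lower number.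

The compounds shown leave open whether both hydroxyl groups are needed, and 4-hydroxyphenyl on the same carbon would test that directly. They also leave open whether the lower number is tied to hydroxyl itself, which a ring carrying an amine or a carboxylic acid in its place could help to settle.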